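The source may hold more compounds than are shown below. What is called first, only, known or untested is meant among the compounds shown, and "the series" means these compounds.

Working notes on the series.

Compound 1 `CC(CCc1cccc(OCc2ccc3ccccc3n2)c1)Cc1nnn[nH]1` carries a tetrazole on a methyl-branched chain and in an assay on membranes from lung (Cavia porcellus) for binding affinity to cysteinyl leukotriene receptor (Homo sapiens) (a lower number here means a stronger inhibitor, a higher number a weaker inhibitor), compound 1 gives 17 nM. Compound 2 `CC(CCCC(=O)O)c1cccc(OCc2ccc3ccccc3n2)c1` carries a carboxylic acid on a methyl-branched chain and in this assay compound 2 gives 90 nM. Compound 3 `c1cc(OCCCc2nnn[nH]2)cc(OCc2ccc3ccccc3n2)c1` carries the tetrazole on a propoxy chain and in this assay compound 3 gives 42 nM. Among the three numbers compound 3 stands second highest: compound 2 sits a step above it, compound 1 a larger step below it.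

Compound 4 `CC(Cc1cccc(OCc2ccc3ccccc3n2)c1)CC(C)C(=O)O` differs from compound 3 in one place: 4-carboxy-2-methylpentyl in place of 3-(1H-tetrazol-5-yl)propoxy on an aromatic carbon. Within the data shown here, the one measured step that bears on this is the exchange of acid chain for tetrazole chain, a 2.1-fold lower number from compound 2 to compound 3 (0.33 log units; beyond the scatter), which went to a lower number. The move from compound 3 to compound 4 runs the other way, tetrazole chain out and acid chain in, so the expectation in this assay is a modest step to a higher number, roughly the size of that measured step; compound 1 shows that a chain bound through carbon rather than oxygen need not hurt.

For compound 4 the expected step is a 1.8-fold higher number from compound 3 to compound 4 (0.25 log units; within the scatter), giving an estimated 75 nM with a range from 25 nM to 220 nM.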

Compound 4, inhibition constant: 24 nM
Compound 4: middle estimate off by 3.1-fold (0.49 log units), on the high side; measured number outside the range, below it.
By their numbers in this assay, from the lowest: compounds 1, 4 and 3 (each within the scatter of the next, the first and the last beyond it); then compound 2.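

At this aromatic carbon a carboxylic acid chain can match a tetrazole chain: in this assay the 4-carboxy-2-methylpentyl group stands level with 3-(1H-tetrazol-5-yl)propoxy (a 1.8-fold lower number from compound 3 to compound 4 (0.24 log units; within the scatter)), and the carbon-linked tetrazole chain of compound 1 also stays level with compound 4 (a 1.4-fold higher number from compound 1 to compound 4 (0.15 log units; within the scatter)), so the earlier gain on moving from acid chain to tetrazole chain does not hold for every acid chain. The clear change comes between the two acid chains, where 4-carboxy-2-methylpentyl in place of 4-carboxy-1-methylbutyl gives a 3.8-fold lower number from compound 2 to compound 4 (0.57 log units; beyond the scatter), showing that in this pair the shape of the chain, with the acid kept, moves the number beyond the scatter. Nothing at hand accounts for any of these steps.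

An unbranched pentyl chain ending in a carboxylic acid would show how much of the result for compound 4 rests on its methyl branches. Also open, on these data alone, is whether an acylsulfonamide or a primary amide could stand in for the carboxylic acid on this same chain.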